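A few compounds are considered here, and "the series" means these few. Any claim that something is new, unique, unknown or untested is made for them only; others in the source may bear on it.

Series notes, read-out a functional assay for inhibition, with Homo sapiens as the target; on this read-out lower numbers stand for stronger inhibition and higher numbers for weaker inhibition. Of the compounds shown here, three have numbers so far. Compound 1 `COC(=O)[C@H](CC1CCCCC1)Nc1nc2ccccc2o1` gives 5 nM, compound 2 `Clc1ccccc1C(CC1CCCCC1)Nc1nc2ccccc2o1` gives 80 nM, and compound 3 `CNC(=O)C(CC1CCCCC1)Nc1nc2cc(C)ccc2o1` gives 72 nM. Compound 3 therefore sits level with compound 2, within the scatter, while compound 1 has a clearly lower number than either.

The next compound is compound 4 `Cc1ccc2oc(NC(CC3CCCCC3)C3=CN(C)NO3)nc2c1`, which is compound 3 with one change: a group of 6 heavy atoms (3 carbon, 2 nitrogen, 1 oxygen; one five-membered non-aromatic ring with 3 hetero atoms) in place of a group of 4 heavy atoms (2 carbon, 1 nitrogen, 1 oxygen; no ring), on a saturated chain carbon bound to a nitrogen on an aromatic ring and a saturated chain carbon. The methylcarbamoyl gives way to a group with a five-membered non-aromatic ring with 3 hetero atoms, on the saturated chain carbon bound to a nitrogen on an aromatic ring and a saturated chain carbon.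

Among the compounds with values here, no measured pair differs in one place only, so no direct precedent exists for this change. The groups at this carbon already differ among the measured compounds, and the numbers run from compound 1 at 5 nM to compound 2 at 80 nM. That spread argues for a wide range with no firm direction. The expected change, a 1.3-fold higher number from compound 3 to compound 4 (0.10 log units; within the scatter), is estimated to stay within the scatter, with more room towards weaker inhibition than stronger. For compound 4 the estimated value is 90 nM, with an expected range from 20 nM to 400 nM.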

Compound 4, half-maximal inhibitory concentration: 26 nM
Compound 4: the middle estimate sits 3.5-fold (0.54 log units) above what was measured; low and high end bracket the measured number.
By their numbers in this assay, from the lowest: compound 1; then compound 4; then compounds 3 and 2 (each within the scatter of the next).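

In this assay, the series now has its first comparison of compounds that differ in one place, and it gives a 2.8-fold lower number from compound 3 to compound 4 (0.44 log units; beyond the scatter). This modest step shows that the methylcarbamoyl is not needed on the saturated chain carbon bound to a nitrogen on an aromatic ring and a saturated chain carbon, since a group with a five-membered non-aromatic ring with 3 hetero atoms gives the lower number there. The two groups share 1 hydrogen-bond donor and 1 double bond outside aromatic rings but differ in the ring, in heavy atoms (4 against 6) and in hydrogen-bond acceptors (1 against 3), and no measurement at hand gives a reason for the step.

As far as these compounds go, a single pair cannot separate these differences, so it remains open whether an open-chain group at this carbon, such as a carboxylic acid, a dimethylamino group or a longer chain, would follow the ring group or the methylcarbamoyl. From the compounds shown here alone, it also remains open whether the same exchange gives a step of like size without the methyl on the shared core.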